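Swapping the nitrogen group: oxolan-3-yl to benzyl

The source may hold more compounds than are shown below. What is called first, only, known or untested is meant among the compounds shown, and "the series" means these compounds.

Measured in a functional assay on HT-29 cells (Homo sapiens) for inhibition, read by luminescence and CellTiter-Glo, with a stated time of 24 h; on this read-out lower numbers stand for an effect already at smaller amounts and higher numbers for an effect only at larger amounts of compound:
Compound 1 `CN1C(=S)[C@@H](NC(=O)c2nc(Cc3ccccc3)n(CCC(F)(F)F)n2)COc2ccccc21`: 1550 nM
Compound 2 `CN1C(=S)[C@@H](NC(=O)c2nc(Cc3ccccc3)n(C3CCC3)n2)COc2ccccc21`: 181 nM
Compound 3 `CN1C(=S)[C@@H](NC(=O)c2nc(Cc3ccccc3)n(C3CCOC3)n2)COc2ccccc21`: 1580 nM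

Compound 3 stands at the high end of these numbers. It shares that end with another value: a 1.0-fold higher number from compound 1 to compound 3 (0.01 log units; within the scatter). The next compound, compound 4 `CN1C(=S)[C@@H](NC(=O)c2nc(Cc3ccccc3)n(Cc3ccccc3)n2)COc2ccccc21`, keeps the shared core and changes one group: benzyl in place of oxolan-3-yl on an aromatic nitrogen.

The measured steps at this same nitrogen bear on the change. Among the compounds with values here, only one group, cyclobutyl, gave a clearly lower number: an 8.6-fold lower number from compound 1 to compound 2 (0.93 log units; beyond the scatter). Swapping it for oxolan-3-yl gave an 8.7-fold higher number from compound 2 to compound 3 (0.94 log units; beyond the scatter). Benzyl itself is untested, but like cyclobutyl it brings a ring of carbon only, whereas oxolan-3-yl has an oxygen in its ring. Three groups are too few to make this a rule, so only part of the cyclobutyl gain is counted on. The estimated step in this assay is a 4.0-fold lower number from compound 3 to compound 4 (0.60 log units; beyond the scatter), expected to be a move to a lower number but smaller than those steps. For compound 4 the estimate is 400 nM, expected to fall between 100 nM and 1600 nM.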

Compound 4, half-maximal effective concentration: 414 nM
For compound 4 the middle estimate is 1.0-fold (0.01 log units) below the measured one, and the stated range covers the measured number.
By their numbers in this assay, from the lowest: compound 2; then compound 4; then compounds 1 and 3 (each within the scatter of the next).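

In this assay benzyl proves better than the two higher-number groups at this aromatic nitrogen, both oxolan-3-yl (a 3.8-fold lower number from compound 3 to compound 4 (0.58 log units; beyond the scatter)) and 3,3,3-trifluoropropyl (a 3.7-fold lower number from compound 1 to compound 4 (0.57 log units; beyond the scatter)). It does not match cyclobutyl, however (a 2.3-fold higher number from compound 2 to compound 4 (0.36 log units; beyond the scatter)), so the two groups with carbon-only rings are not interchangeable here. Across these four compounds, cyclobutyl and benzyl both give lower numbers than oxolan-3-yl and 3,3,3-trifluoropropyl, and no compound shown goes against that order, although four groups remain a small sample.

On these data alone, whether a cyclopentyl group or a chain ending in an amine at this nitrogen would go below compound 2 remains open. Nothing shown here explains why these groups differ.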